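Swapping 3-fluorobenzyl for 2-chlorobenzyl in compound 3

This account rests on a few compounds, and the source may have more. Where it says the series, first, only, none or still open, it means among the compounds named here.

Among the compounds with values here, in a functional assay on GBM1 cells (Homo sapiens) for antiproliferative activity, read by WST assay, with a stated time of 72 h (on this read-out higher numbers stand for weaker inhibition and lower numbers for stronger inhibition), compound 3 `O=C(Nc1cc2ncncc2cc1OCc1cccc(F)c1)Nc1cccc2ccccc12` gives 1300 nM and holds the lowest of the three numbers so far. Compound 4 `O=C(Nc1cc2ncncc2cc1OCc1ccccc1Cl)Nc1cccc2ccccc12` carries 2-chlorophenyl in place of 3-fluorophenyl on a saturated chain carbon bound to an oxygen on an aromatic ring. Within the data shown here, compound 1 `O=C(Nc1cc2ncncc2cc1OCc1ccc(Cl)cc1)Nc1cccc2ccccc12` has 4-chlorophenyl at that place and gives 7900 nM in the one measured step that bears on this change, a 6.1-fold lower number from compound 1 to compound 3 (0.78 log units; beyond the scatter) and modest in size. Compound 2 `O=C(Nc1cccc(F)c1)Nc1cc2ncncc2cc1OCc1ccccc1Cl` carries the same 2-chlorophenyl but differs elsewhere, and gives 4000 nM on this read-out. A modest rise is therefore expected, an estimated 2.3-fold higher number from compound 3 to compound 4 (0.36 log units; beyond the scatter) in this assay and smaller than the step just described. For compound 4 the estimate is 3000 nM with an expected range from 1000 nM to 8000 nM on this read-out.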

Compound 4, half-maximal inhibitory concentration: 2900 nM
The estimate for compound 4 lay 1.0-fold (0.01 log units) above the measured number, within the range that was stated.
By their numbers in this assay, from the lowest: compound 3; then compounds 4, 2 and 1 (each within the scatter of the next, the first and the last beyond it).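

In this assay, with naphthalen-1-yl on the amide-type nitrogen, 2-chlorophenyl falls between the other two groups at this place, with 4-chlorophenyl replaced in a 2.7-fold lower number from compound 1 to compound 4 (0.44 log units; beyond the scatter) and 3-fluorophenyl replaced in a 2.2-fold higher number from compound 3 to compound 4 (0.35 log units; beyond the scatter). With 2-chlorophenyl held, the two groups on the amide-type nitrogen are not told apart, as a 1.4-fold lower number from compound 2 to compound 4 (0.14 log units; within the scatter) stays within the scatter. No measurement at hand accounts for these differences.

The compounds shown leave open whether the kind of halogen or its place on the ring governs these steps, which 3-chlorophenyl at this place would help separate. They also leave open how an unsubstituted phenyl or a pyridinyl would compare.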